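The source may report more compounds than this note shows. Statements on the series, on what has been measured and on what is new or still open speak of the compounds shown alone.

Compound 1 `C=C1C(=O)[C@@]23C(=O)OC[C@]4([C@@H](OC(C)=O)CCC(C)(C)[C@H]4C=O)[C@@H]2CC[C@H]1[C@H]3OC(=O)c1ccc(OC)cc1` belongs to a small set of three compounds built on the same core and differing only in the group on the aromatic ring of the ester. In a functional assay on Bel-7402 cells (Homo sapiens) for inhibition, read by MTT assay (a lower number here means a stronger inhibitor, a higher number a weaker inhibitor), compound 1 gives 2470 nM, the second highest of the three numbers. Compound 2 `C=C1C(=O)[C@@]23C(=O)OC[C@]4([C@@H](OC(C)=O)CCC(C)(C)[C@H]4C=O)[C@@H]2CC[C@H]1[C@H]3OC(=O)c1ccc(C)cc1` gives 2090 nM, and a 1.2-fold lower number from compound 1 to compound 2 (0.07 log units; within the scatter). Compound 3 `C=C1C(=O)[C@@]23C(=O)OC[C@]4([C@@H](OC(C)=O)CCC(C)(C)[C@H]4C=O)[C@@H]2CC[C@H]1[C@H]3OC(=O)c1ccc(C(F)(F)F)cc1` gives 5090 nM; a 2.1-fold higher number from compound 1 to compound 3 (0.31 log units; beyond the scatter), and a 2.4-fold higher number from compound 2 to compound 3 (0.39 log units; beyond the scatter).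

The next compound, compound 4 `C=C1C(=O)[C@@]23C(=O)OC[C@]4([C@@H](OC(C)=O)CCC(C)(C)[C@H]4C=O)[C@@H]2CC[C@H]1[C@H]3OC(=O)c1ccccc1`, differs from compound 1 in a single place: hydrogen in place of methoxy on an aromatic carbon. Among the measured compounds shown here, none of the measured steps removes the aromatic group altogether, so their bearing is indirect. The step from compound 1 to compound 2 shows that swapping methoxy for methyl stays within the scatter, while both steps to compound 3 show that trifluoromethyl brings a modest rise. Hydrogen in place of methoxy is a third kind of change, with no measured counterpart, and only a small step is anticipated, more likely upward than downward.

Compound 4 is therefore expected to give 2800 nM, with a range from 1400 nM to 5600 nM. That expectation amounts to a 1.1-fold higher number from compound 1 to compound 4 (0.05 log units; within the scatter).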

Compound 4, half-maximal inhibitory concentration: 3050 nM
Beside the measured number, compound 4's estimate is 1.1-fold (0.04 log units) below it; the measured number falls inside the stated range.
By their numbers in this assay, from the lowest: compounds 2, 1, 4 and 3 (each within the scatter of the next, the first and the last beyond it).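

In this assay this place on the ring needs no substituent to hold its number: hydrogen in place of methoxy gives a 1.2-fold higher number from compound 1 to compound 4 (0.09 log units; within the scatter) and leaves the 4-methoxyphenyl and phenyl esters indistinguishable. Among the compounds shown here, compound 4 also lies within the scatter of the other two esters, with a 1.5-fold higher number from compound 2 to compound 4 (0.16 log units; within the scatter) and a 1.7-fold lower number from compound 3 to compound 4 (0.22 log units; within the scatter), so neither methyl nor trifluoromethyl, read against hydrogen, moves the number beyond the scatter, and only the pair joined by a 2.4-fold higher number from compound 2 to compound 3 (0.39 log units; beyond the scatter) remains separated beyond it. Nothing available gives a reason for any of these steps.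

Still open, going by these compounds, is whether a group of another kind on this aromatic carbon, such as an amine, a carboxylic acid or a longer alkoxy chain, would carry the number beyond the scatter of compound 4. Also open, on these data alone, is how the number would respond if a free hydroxyl stood in place of the whole benzoyloxy group on the shared core.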